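The source may report more compounds than this note shows. Statements on the series, on what has been measured and on what is new or still open speak of the compounds shown alone.

Working notes on the series. The shared core of compound 1 `CCCc1nc(-c2ccccc2)c(CNCCN2CCN(c3cccc(C(F)(F)F)c3)CC2)o1` carries an aryl group on the amine nitrogen of the six-membered ring with two nitrogens. In an assay on HEK293 cells for inhibition of Voltage-dependent T-type calcium channel subunit alpha-1G (Homo sapiens), read by patch clamp (a lower number here means a stronger inhibitor, a higher number a weaker inhibitor), compound 1 gives 1940 nM. Compound 2 `CCCc1nc(-c2ccccc2)c(CNCCCN2CCN(c3cccc(Cl)c3)CC2)o1` gives 1750 nM and compound 3 `CCCc1nc(-c2ccccc2)c(CNCCCN2CCN(c3cccc(C)c3C)CC2)o1` gives 1780 nM; both values sit within the scatter of the value for compound 1, so the three are not separated by this assay.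

Going by the values given here, the only measured step that bears on the aryl group is a 1.0-fold higher number from compound 2 to compound 3 (0.01 log units; within the scatter). One exchange of that aryl group therefore leaves the number where it was.

Compound 4 `CCCc1nc(-c2ccccc2)c(CNCCN2CCN(c3ccccc3C)CC2)o1` differs from compound 1 by 2-methylphenyl in place of 3-(trifluoromethyl)phenyl on an amine nitrogen in a ring. Among the compounds with values here, the one comparable step gives no sign of movement, so no change beyond the scatter is expected in this assay. The expected step from compound 1 to compound 4 is a 1.0-fold lower number from compound 1 to compound 4 (0.01 log units; within the scatter). Compound 4 is estimated at 1900 nM, with a range from 700 nM to 5000 nM.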

Compound 4, half-maximal inhibitory concentration: 4300 nM
Estimate against measurement, compound 4: 2.3-fold (0.35 log units) below, within the range that was stated.
By their numbers in this assay, from the lowest: compounds 2, 3 and 1 (each within the scatter of the next); then compound 4.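

On an amine nitrogen in a ring, the aryl group is not always silent in this assay: the exchange in compound 4 gives a modest step beyond the scatter (a 2.2-fold higher number from compound 1 to compound 4 (0.35 log units; beyond the scatter)), whereas the earlier aryl exchange stayed within it (a 1.0-fold higher number from compound 2 to compound 3 (0.01 log units; within the scatter)). Among the compounds that differ in this one place, the position therefore shows some sensitivity to which aryl group it carries, with 2-methylphenyl giving the weaker inhibitor of the pair. No measurement at hand accounts for this step.

The exchange alters both the substituent and its place on the phenyl ring, and a 3-methylphenyl group on the same nitrogen would separate those two changes. Also open, on these data alone, is whether 2-methylphenyl gives a similar step on the longer chain carried by compound 2 and compound 3.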